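A few compounds are considered here, and "the series" means these few. Any claim that something is new, unique, unknown or untested is made for them only; others in the source may bear on it.

Series notes. All three compounds share one core; compound 1 is `O=C(N/N=C/c1ccc(Cl)cc1)c1cnccn1` and compound 2 is `O=C(N/N=C/c1cccc(Br)c1)c1cnccn1`. In an ADME assay on J774 cells (Mus musculus) for cytotoxicity, read by MTT assay, with a stated time of 48 h, tested at 100 ug/mL (a higher number here means a weaker effect of the compound at the concentration tested, a lower number a stronger effect), compound 1 gives 64%, the lowest of the two numbers recorded so far, while compound 2 gives 100%, a number higher by a margin beyond the usual scatter of this read-out. Compound 3, `CN(C)c1ccc(/C=N/NC(=O)c2cnccn2)cc1`, has not yet been measured. Against compound 1 it shows (dimethylamino in place of chloro on an aromatic carbon). Within the data shown here, no measured pair isolates this change, so its size is open; the move in this assay is expected to be modest and upward, towards a weaker effect at the tested concentration, with a result inside the scatter of compound 1 also plausible. Compound 3 is therefore expected to give about 80%, within 55% to 100%, which corresponds to an expected shift of a number 16 percentage points higher from compound 1 to compound 3 (beyond the scatter).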

Compound 3, a percentage reported as activity, at one concentration (the size of the read-out at that concentration, not a potency): 87%
For compound 3 the middle estimate is 7 percentage points below the measured one, within the range that was stated.
By their numbers in this assay, from the lowest: compound 1; then compound 3; then compound 2.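

Dimethylamino in place of chloro on an aromatic carbon, para to a large group, gives a number 23 percentage points higher from compound 1 to compound 3 (beyond the scatter) in this assay, the only single-place comparison in the series so far. At this position, the stronger effect seen with chloro at the tested concentration therefore does not carry over to dimethylamino, so the substituent here does affect the read-out. Nothing available explains this shift.

A single pair cannot show whether the shift follows from losing chloro or from gaining dimethylamino, and compound 2 differs from both compounds in more than one place, so it cannot settle this. As far as these compounds go, whether plain hydrogen, a methoxy group or a carboxylic acid at this position would fall nearer compound 1 or compound 3 remains open.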